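A few compounds are considered here, and "the series" means these few. Any claim that something is new, unique, unknown or untested is made for them only; others in the source may bear on it.

Three compounds share a core in which a pyrrole ring is fused to a benzene ring, with an acetyl group and two aryl groups attached. Compound 1 is `CC(=O)c1cc(-c2ccc(F)cc2)cc2cc(-c3ccccc3)[nH]c12`, compound 2 is `COc1ccc(-c2cc(C(C)=O)c3[nH]c(-c4ccccc4)cc3c2)cc1` and compound 3 is `CC(=O)c1cc(-c2ccccc2)cc2cc(-c3ccc(F)cc3)[nH]c12`. In a functional assay on MCF7 cells (Homo sapiens) for cytotoxicity, read by MTT assay, with a stated time of 2 days, tested at 0.1 uM (on this read-out lower numbers stand for a stronger effect and higher numbers for a weaker effect at the one concentration tested), compound 1 gives 98.3%, compound 2 gives 99.2% and compound 3 gives 98.5%. All three numbers sit close together, and none of the gaps between them exceeds the usual scatter of this kind of measurement.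

One structural change has been measured directly. Going from compound 1 to compound 2, the change is methoxy in place of fluoro on an aromatic carbon, and the step it made was a number 0.9 percentage points higher from compound 1 to compound 2 (within the scatter). Compound 3 and compound 1 are built from the same atoms joined differently, and the difference between the two cores is not broken down here.

Compound 4 is `COc1ccc(-c2cc3cc(-c4ccccc4)cc(C(C)=O)c3[nH]2)cc1` and has not yet been tested. Among the measured compounds shown here, it differs from compound 3 by methoxy in place of fluoro on an aromatic carbon, which is the same change as the one from compound 1 to compound 2, made at the same kind of place. Because the step of a number 0.9 percentage points higher from compound 1 to compound 2 (within the scatter) stayed within the scatter, the step from compound 3 to compound 4 is expected to be a number 0.5 percentage points higher from compound 3 to compound 4 (within the scatter). On that basis compound 4 is estimated to give 99% in this assay, with a range from 94% to 100%.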

Compound 4, a percentage reported as activity, at one concentration (the size of the read-out at that concentration, not a potency): 87%
Compound 4: middle estimate off by 12 percentage points, on the high side; the measured number lies below the stated range.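

In this assay, replacing 4-fluorophenyl with 4-methoxyphenyl gave a number 11.5 percentage points lower from compound 3 to compound 4 (beyond the scatter), while the same change on the other core stayed within the scatter. Set side by side, the two steps cannot be told apart, so the data do not show that this change behaves differently on the two cores: the same change on two cores in this assay, a number 0.9 percentage points higher (within the scatter) from compound 1 to compound 2 and a number 11.5 percentage points lower (beyond the scatter) from compound 3 to compound 4, 12.4 percentage points apart, within the scatter of two such steps. Among the compounds shown here, the result therefore neither proves that the step carries over from one core to the other nor proves that it fails to, and with only one pair on each core, the lower number for compound 4 is a single modest reading rather than a rule for the series.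

The compounds shown leave open what other groups in the same place on the aryl ring, such as an amine, a carboxylic acid or a longer chain like butoxy, would do on either core, and whether any of them would separate the two cores clearly. They also leave open how compound 4 would behave at other concentrations, since a reading at one concentration gives the size of an effect there and not a potency.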